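Bicyclic diamine in place of hydroxypyrrolidine on the chain

The source may hold more compounds than are shown below. What is called first, only, known or untested is meant among the compounds shown, and "the series" means these compounds.

For the measured compounds named here, compound 1 `NCc1ncc([C@]23CC[C@@H](N(CCN4CC[C@H](O)C4)C(=O)Nc4ccc(F)c(C(F)(F)F)c4)C2C3)s1` gives 99 nM in a functional assay for antagonist activity at melanin-concentrating hormone receptor 1 (Homo sapiens) (a lower number here means a stronger inhibitor, a higher number a weaker inhibitor), the higher of the two numbers known so far. Compound 2 `C[C@@H]1CN(CCCN(C(=O)Nc2cc(Cl)nc(Cl)c2)[C@@H]2CC[C@]3(c4cnc(CN)s4)CC23)[C@@H](C)CN1` gives 13.1 nM in this assay, and its step down from compound 1 lies beyond the scatter; the two compounds differ in several places, so no single change can be held responsible. Compound 3 `NCc1ncc([C@]23CC[C@@H](N(CCCN4CC5CC4CN5)C(=O)Nc4ccc(F)c(C(F)(F)F)c4)C2C3)s1` has not yet been measured. It differs from compound 1 in that it carries a group of 8 heavy atoms (6 carbon, 2 nitrogen; 2 five-membered non-aromatic rings with 1 hetero atom each) in place of a group of 6 heavy atoms (4 carbon, 1 nitrogen, 1 oxygen; one five-membered non-aromatic ring with 1 hetero atom), on a saturated chain carbon, two bonds along the chain from an amide-type nitrogen. Compound 2 also carries a diamine on its chain and has the lower number, which gives some ground to expect a lower number for compound 3, though it rests on one comparison only. The step from compound 1 to compound 3 is expected to be a 2.2-fold lower number from compound 1 to compound 3 (0.34 log units; beyond the scatter). In this assay compound 3 is therefore estimated to give 45 nM, with a range from 12 nM to 160 nM.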

Compound 3, inhibition constant: 73 nM
Beside the measured number, compound 3's estimate is 1.6-fold (0.21 log units) below it, within the range that was stated.
By their numbers in this assay, from the lowest: compound 2; then compounds 3 and 1 (each within the scatter of the next).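

The step of a 1.4-fold lower number from compound 1 to compound 3 (0.13 log units; within the scatter) in this assay shows that, on a saturated chain carbon, two bonds along the chain from an amide-type nitrogen, the 3-hydroxypyrrolidin-1-yl group and the group with two five-membered rings cannot be told apart. For the compounds shown here, this is the first comparison in which only this place differs, and it shows that a hydroxyl oxygen is not needed there for a reading of this size, since compound 3 has none and gives 73 nM. No evidence bearing on this result is at hand.

As far as these compounds go, it remains open whether a simple piperazine, a morpholine or a dimethylamino group at this place, with the rest of compound 1 unchanged, would also read alike. From the compounds shown here alone, it is equally open whether the same exchange would give the same small step on a different aryl group.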